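Acyl group swap on the amide: pyrrole to isobutyl

The source may report more compounds than this note shows. Statements on the series, on what has been measured and on what is new or still open speak of the compounds shown alone.

Values in a functional assay on A2780 cells (Homo sapiens) for inhibition, read by sulforhodamine B assay, with a stated time of 3 days; on this read-out lower numbers stand for stronger inhibition and higher numbers for weaker inhibition:
compound 1 `COc1ccc(C(=O)Nc2ccc3c(c2)/C(=C/Nc2cccc(N4CCN(C)CC4)c2)C(=O)N3)cc1`: 2050 nM
compound 2 `CN1CCN(c2cccc(N/C=C3\C(=O)Nc4ccc(NC(=O)c5cccc(F)c5)cc43)c2)CC1`: 2910 nM
compound 3 `CN1CCN(c2cccc(N/C=C3\C(=O)Nc4ccc(NC(=O)c5ccc[nH]5)cc43)c2)CC1`: 4460 nM

Compound 3 carries the highest of the three numbers, but that position is only partly resolved. The measured steps to it are a 2.2-fold higher number from compound 1 to compound 3 (0.34 log units; beyond the scatter) and a 1.5-fold higher number from compound 2 to compound 3 (0.19 log units; within the scatter), and only the first clears the scatter.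

The next compound is compound 4 `CC(C)CC(=O)Nc1ccc2c(c1)/C(=C/Nc1cccc(N3CCN(C)CC3)c1)C(=O)N2`, which keeps the shared core and has isobutyl in place of 1H-pyrrol-2-yl on a carbonyl carbon.

All three measured steps change the group at this same place. The remaining one is a 1.4-fold higher number from compound 1 to compound 2 (0.15 log units; within the scatter). Across these aromatic groups the largest step is therefore the modest one to compound 3, and the other two stay within the scatter. Within the data shown here, none of the measured compounds has a group without a ring here, so these steps are only indirect guides to isobutyl, and the range is kept wide.

No step beyond the scatter is expected in this assay, and the direction is open. The expected step is a 1.3-fold lower number from compound 3 to compound 4 (0.11 log units; within the scatter). Compound 4 is estimated at 3500 nM, with an expected range of 1500 nM to 8000 nM.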

Compound 4, half-maximal inhibitory concentration: 3370 nM
Compound 4: middle estimate off by 1.0-fold (0.02 log units), on the high side, and the stated range covers the measured number.
By their numbers in this assay, from the lowest: compounds 1, 2, 4 and 3 (each within the scatter of the next, the first and the last beyond it).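

In this assay, among these compounds, compound 4 is the first in this set with a group without a ring on the carbonyl carbon, and all of its steps stay within the scatter: (a 1.3-fold lower number from compound 3 to compound 4 (0.12 log units; within the scatter)), (a 1.2-fold higher number from compound 2 to compound 4 (0.06 log units; within the scatter)) and (a 1.6-fold higher number from compound 1 to compound 4 (0.22 log units; within the scatter)). Among these four compounds, an aromatic ring at this place is therefore not needed to keep the number in this range, and neither is the hydrogen-bond donor that leaves with 1H-pyrrol-2-yl, since isobutyl has neither. Compound 4 does not separate the aromatic groups any further, the step from compound 1 to compound 3 remains the only one beyond the scatter, and no supporting data bear on why this place responds so little to the change.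

Still open, as far as these compounds go, is whether the flat response holds for groups of a different kind at this place, such as an amine, a carboxylic acid or a longer chain. Also open, from the compounds shown here alone, is whether any group on this carbonyl carbon can move the number well beyond the narrow range seen so far, or whether changes elsewhere on the shared core matter more.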